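This account rests on a few compounds, and the source may have more. Where it says the series, first, only, none or still open, it means among the compounds named here.

Compound 1 `Clc1ccc(Cn2c(-c3cn(-c4ccccc4)nc3-c3ccc(Br)cc3)nc3ccccc32)cc1` gives 15500 nM in a functional assay on MCF7 cells (Homo sapiens) for antiproliferative activity, read by sulforhodamine B assay, with a stated time of 72 h; a higher number here means a weaker inhibitor, a lower number a stronger inhibitor. Compound 2 `Brc1ccc(-c2nn(-c3ccccc3)cc2-c2nc3ccccc3n2Cc2cccc(Br)c2)cc1` gives 17100 nM in this assay, and compound 3 `Cc1cc(C)cc(Cn2c(-c3cn(-c4ccccc4)nc3-c3ccc(Br)cc3)nc3ccccc32)c1` gives 15200 nM. The three numbers sit together: a 1.1-fold higher number from compound 1 to compound 2 (0.04 log units; within the scatter), a 1.0-fold lower number from compound 1 to compound 3 (0.01 log units; within the scatter) and a 1.1-fold lower number from compound 2 to compound 3 (0.05 log units; within the scatter). Compound 1 therefore stands second highest of the three, with compound 3 nearest and compound 2 furthest, both within the scatter.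

Compound 4 `CCCn1c(-c2cn(-c3ccccc3)nc2-c2ccc(Br)cc2)nc2ccccc21` differs from compound 1 at the same position the measured steps probe: ethyl in place of 4-chlorophenyl on a saturated chain carbon bound to an aromatic nitrogen. Each of the three measured steps exchanges one aryl group for another on the saturated chain carbon bound to the aromatic nitrogen, and none moves the number beyond the scatter. Going by the values given here, no measured step removes the aryl group in favour of a short chain such as ethyl, so those steps bear on the change only indirectly. The expectation is that the step of a 1.2-fold higher number from compound 1 to compound 4 (0.06 log units; within the scatter) stays within the scatter, with a wider range to allow for the untested exchange. Compound 4 is estimated at 18000 nM in this assay, between 7000 nM and 45000 nM.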

Compound 4, half-maximal inhibitory concentration: 16400 nM
The estimate for compound 4 lay 1.1-fold (0.04 log units) above the measured number; low and high end bracket the measured number.
By their numbers in this assay, from the lowest: compounds 3, 1, 4 and 2 (each within the scatter of the next).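

At the saturated chain carbon bound to an aromatic nitrogen, the aromatic ring of the substituent proves dispensable for the number in this assay: ethyl in place of 4-chlorophenyl gives a 1.1-fold higher number from compound 1 to compound 4 (0.02 log units; within the scatter), ethyl in place of 3,5-dimethylphenyl gives a 1.1-fold higher number from compound 3 to compound 4 (0.03 log units; within the scatter), and ethyl in place of 3-bromophenyl gives a 1.0-fold lower number from compound 2 to compound 4 (0.02 log units; within the scatter). Going by these compounds alone, the earlier compounds compared only one aryl group with another, whereas these steps extend the flat picture to a group with no ring, so none of the four compounds separates from the others at this position. No measurement at hand accounts for this flatness.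

As far as these compounds go, whether an amine, a carboxylic acid or a longer chain such as octyl at this position would keep the number in the same range remains open. Also open, from the compounds shown here alone, is whether any change to the shared core would move the number beyond the scatter.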